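One More Carbon on the Short Side Chain

The compounds below may be only part of what the source reports. "The series", "measured", "known", "first", "only" and "open" are said of these compounds alone.

Of the compounds shown here, two have so far been measured in a functional assay on HCT-116 cells (Homo sapiens) for cytotoxicity, read by sulforhodamine B assay (a higher number here means that more compound is needed for the effect, a lower number that less compound is needed), compound 1 (`CCCCCCCCCCCCC/C=C/[C@@H](O)[C@H](CO)n1cc(CCC)nn1`) and compound 2 (`CCCCCCCCCCCCCC[C@@H](O)[C@@H](O)[C@H](CO)n1cc(CCC)nn1`). In this assay compound 1 gives 16000 nM and compound 2 gives 13900 nM on the same read-out. Compound 2 therefore stands level with compound 1, since the two numbers lie within the usual scatter of each other.

The next compound, compound 3 (`CCCCCCCCCCCCCC[C@@H](O)[C@@H](O)[C@H](CO)n1cc(CCCC)nn1`), departs from compound 2 by a single change: methyl in place of hydrogen on a saturated chain carbon, three bonds along the chain from an aromatic carbon. The same difference can be read as propyl to butyl. Among the compounds with values here, no measured pair shows this change, so the data give no direct guide to its size. For so small a change, no step beyond the scatter is expected in this assay in either direction. The estimate amounts to a 1.2-fold lower number from compound 2 to compound 3 (0.06 log units; within the scatter) and this expected step stays within the scatter. For compound 3 the expected value is 12000 nM with an estimated range from 6000 nM to 22000 nM as the likely span of a measurement.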

Compound 3, half-maximal effective concentration: 12900 nM
Compound 3: middle estimate off by 1.1-fold (0.03 log units), on the low side; measured number inside the range.
By their numbers in this assay, from the lowest: compounds 3, 2 and 1 (each within the scatter of the next).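

In this assay, the change from propyl to butyl gives a 1.1-fold lower number from compound 2 to compound 3 (0.03 log units; within the scatter), the first step read between measured compounds that differ in one place. It shows that methyl in place of hydrogen on a saturated chain carbon, three bonds along the chain from an aromatic carbon, leaves compound 3 level with compound 2, so at this position and in this assay the short side chain can carry the added methyl without a step beyond the scatter. This single pair gives no reason for that result, and no other information bears on it.

The compounds shown leave open whether the short side chain has any bearing on this read-out at all, as a single step within the scatter cannot say how far the chain can be taken before the number moves. A longer chain such as octyl, a branched chain such as isobutyl, or an amine or a carboxylic acid at the end of the chain could each give a step beyond the scatter or none, and these compounds do not tell which.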